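This account rests on a few compounds, and the source may have more. Where it says the series, first, only, none or still open, it means among the compounds named here.

Compound 2, `Nc1scc(-c2cccc(C(F)(F)F)c2)c1C(=O)c1ccccc1`, is the compound under discussion. In a functional assay on CHO-K1 cells for agonist activity at adenosine receptor A1 (Homo sapiens), read by GTPgammaS binding (on this read-out lower numbers stand for an effect already at smaller amounts and higher numbers for an effect only at larger amounts of compound), compound 2 gives 15.8 uM, the higher of the two numbers in hand. Its nearest neighbour is compound 1, `CCOC(=O)c1c(-c2cccc(C(F)(F)F)c2)csc1N`, which in this assay gives 9.4 uM; the step of a 1.7-fold higher number from compound 1 to compound 2 (0.23 log units; within the scatter) changes phenyl for ethoxy on the carbonyl carbon. Compound 3, `CCOC(=O)c1c(N)sc(-c2ccc(OC)cc2)c1-c1cccc(C(F)(F)F)c1`, in this assay reaches only a limit, > 10 uM, (the limit of > 10 uM in this assay, at which 1 of the 3 values shown sits). The step from compound 1 to compound 3 therefore shows at most what a floor can show, an at least 1.0-fold higher number from compound 1 to compound 3 (0.02 log units; that floor lies within the scatter), for adding 4-methoxyphenyl on an aromatic carbon of the shared core.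

Compound 4, `Nc1sc(Cl)c(-c2cccc(C(F)(F)F)c2)c1C(=O)c1ccccc1`, differs from compound 2 by chloro in place of hydrogen on an aromatic carbon. For the measured compounds named here, the only measured step at that place is the one from compound 1 to compound 3, which is a floor within the scatter, so no shift beyond the scatter is expected in this assay for the step of a 1.1-fold lower number from compound 2 to compound 4 (0.02 log units; within the scatter). Compound 4 is thus estimated at 15 uM, with a range from 4 uM to 60 uM.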

Compound 4, concentration for half-maximal effect: > 10 uM
Compound 4: only a limit was reported (the forecaster's own chance of this, stated with the estimate: 35%); the middle value does not contradict the limit.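

In this assay, for the compounds shown here, compound 4 reaches only a limit, > 10 uM, so no step from compound 2 to compound 4 can be read: the limit of > 10 uM in this assay, at which 2 of the 4 values shown sit. The compounds shown leave open whether chloro in place of hydrogen on this aromatic carbon shifts the number in this assay at all.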